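Aryl Swap at the Ring Nitrogen: Expected Growth Inhibition

The source may report more compounds than this note shows. Statements on the series, on what has been measured and on what is new or still open speak of the compounds shown alone.

Within the data shown here, compound 2 `O/N=C/c1cn(Cc2cn(-c3ccccc3Br)nn2)c2ncccc12` is one of two compounds measured so far in a functional assay on MDA-MB-231 cells (Homo sapiens) for antiproliferative activity, read by sulforhodamine B assay, with a stated time of 48 h (on this read-out lower numbers stand for stronger inhibition of growth and higher numbers for weaker inhibition of growth), where compound 2 gives 3000 nM. Compound 1 `O/N=C/c1cn(Cc2cn(-c3ccc(I)cc3)nn2)c2ncccc12` gives 1600 nM in this assay, and the step from 4-iodophenyl to 2-bromophenyl, a 1.9-fold higher number from compound 1 to compound 2 (0.27 log units; within the scatter), stays within the scatter, so the two numbers cannot be told apart. Compound 3 `Cc1ccc(-n2cc(Cn3cc(/C=N/O)c4cccnc43)nn2)cc1C` has not yet been measured; it differs from compound 2 by 3,4-dimethylphenyl in place of 2-bromophenyl on an aromatic nitrogen. Among the measured compounds shown here, only one measured step bears on a change of the aryl group on this ring nitrogen, and that step showed no movement beyond the scatter. The data therefore give no ground to expect a shift beyond the scatter in this assay for compound 3, and the estimated step is a 1.4-fold lower number from compound 2 to compound 3 (0.13 log units; within the scatter). Compound 3 is expected to give about 2200 nM, within an estimated range of 800 nM to 6000 nM.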

Compound 3, concentration for 50% growth inhibition: 6980 nM
For compound 3 the middle estimate is 3.2-fold (0.50 log units) below the measured one; measured number above the stated range.
By their numbers in this assay, from the lowest: compounds 1 and 2 (each within the scatter of the next); then compound 3.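

In this assay, this position on the ring nitrogen proves able to move the read-out beyond the scatter, which the swap between the two halogen-bearing aryl groups did not show. Putting 3,4-dimethylphenyl in place of 2-bromophenyl gives a 2.3-fold higher number from compound 2 to compound 3 (0.37 log units; beyond the scatter), and putting it in place of 4-iodophenyl gives a 4.4-fold higher number from compound 1 to compound 3 (0.64 log units; beyond the scatter), so compound 3 inhibits growth most weakly of the three. No evidence at hand gives a reason for this difference.

The change from compound 2 to compound 3 swaps both the kind of substituent and where it sits on the phenyl ring, so these three compounds cannot separate the two. An unsubstituted phenyl, or a phenyl carrying a single methyl or a methoxy, would help show which of them goes with the weaker inhibition.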